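Moving the ring nitrogen and methyl on the pyridyl arm

This account rests on a few compounds, and the source may have more. Where it says the series, first, only, none or still open, it means among the compounds named here.

Compound 2 `CNCc1cc(-c2cnccc2C)n(S(=O)(=O)c2cccnc2)c1` is the lower of the two compounds measured in a functional assay on the whole organism (strain Jcl:SD) for inhibition, with Rattus norvegicus as the target, with stated times of 3 min and 3 h, at a dose of 1 mg/kg by the intravenous route (a higher number here means more inhibition at the dose given (going by the name of the read-out), a lower number less inhibition), where compound 2 gives -54%. Its nearest comparator is compound 1 `CNCc1cc(-c2cccnc2C)n(S(=O)(=O)c2cccnc2)c1`, which in this assay gives -41%; the step of a number 13 percentage points lower from compound 1 to compound 2 (beyond the scatter) lies beyond the scatter and is a modest one. Compound 3 `CNCc1cc(-c2ncccc2C)n(S(=O)(=O)c2cccnc2)c1` arises from compound 2 by the change (3-methylpyridin-2-yl in place of 4-methylpyridin-3-yl on an aromatic carbon). For the measured compounds named here, the only measured step that bears on this, the exchange of one methylpyridyl for another from compound 1 to compound 2, is of the same kind, and it moved the read-out by a modest amount. A step of similar modest size is therefore expected in this assay for compound 3, with the direction not fixed by the data. The estimate for compound 3 is -45%, with a range from -70% to -20%, which means an expected step of a number 9 percentage points higher from compound 2 to compound 3 (within the scatter).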

Compound 3, a percentage reported as inhibition, in the whole organism at one dose (the size of the read-out at that dose, not a potency) in the Rattus norvegicus assay: 5%
The estimate for compound 3 lay 50 percentage points below the measured number; the whole stated range lies below it.
By their numbers in the Rattus norvegicus assay, from the lowest: compound 2; then compound 1; then compound 3.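

In the Rattus norvegicus assay, the exchange for 3-methylpyridin-2-yl on this aromatic carbon, next to the ring nitrogen, gives steps of a different order from the one between the two earlier methylpyridyl groups: a number 59 percentage points higher from compound 2 to compound 3 (beyond the scatter) and a number 46 percentage points higher from compound 1 to compound 3 (beyond the scatter). So the same atoms, joined differently, can decide most of the read-out here, and the earlier exchange gave no sign of this. In a physicochemical assay for lipophilicity, read by HPLC, at pH 7.4 (on this read-out lower numbers stand for lower lipophilicity and higher numbers for higher lipophilicity), compound 2 gives -0.51 and compound 3 gives 0.53, and the change in inhibition may be connected with this rise in lipophilicity, because the two compounds differ clearly on that scale: the measured distribution coefficient of compound 2, -0.51, and of compound 3, 0.53, a number 1.04 log units higher (beyond the scatter)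

That connection rests on a single pair of compounds, and lipophilicity and the position of the ring nitrogen cannot be separated here. As far as these compounds go, it also remains open whether a methoxy group or an amine in place of the methyl on 3-methylpyridin-2-yl would keep the read-out of compound 3.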